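Propyl to Tert-Butoxy on the Aromatic Carbon: An Estimate

A few compounds are considered here, and "the series" means these few. Any claim that something is new, unique, unknown or untested is made for them only; others in the source may bear on it.

For the measured compounds named here, in an assay on membranes from brain for displacement of a labelled ligand from Neuronal acetylcholine receptor; alpha4/beta2 (Rattus norvegicus), with a stated time of 3 h (on this read-out lower numbers stand for stronger inhibition and higher numbers for weaker inhibition), compound 2 `CCCc1ccc(/C=C2\CCCN=C2c2cccnc2)cc1` gives 890 nM, the lower of the two numbers known here, while compound 1 `CCCCOc1ccc(/C=C2\CCCN=C2c2cccnc2)cc1` gives 1960 nM. Going by the values given here, the one measured step, a 2.2-fold lower number from compound 1 to compound 2 (0.34 log units; beyond the scatter), concerns the same aromatic carbon that changes again now. Compound 3 `CC(C)(C)Oc1ccc(/C=C2\CCCN=C2c2cccnc2)cc1` differs from compound 2 by tert-butoxy in place of propyl on an aromatic carbon. Because compound 1 also carries an alkoxy group at that position and shows 1960 nM, and because the step of a 2.2-fold lower number from compound 1 to compound 2 (0.34 log units; beyond the scatter) was modest, the expected step of a 1.9-fold higher number from compound 2 to compound 3 (0.28 log units; within the scatter) in this assay is a modest rise, roughly undoing that earlier change, with some uncertainty since no branched alkoxy group has been measured. Compound 3 is therefore estimated at 1700 nM in this assay, with a range from 700 nM to 4500 nM.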

Compound 3, inhibition constant: 2170 nM
The estimate for compound 3 lay 1.3-fold (0.11 log units) below the measured number; the range from low to high includes it.
By their numbers in this assay, from the lowest: compound 2; then compounds 1 and 3 (each within the scatter of the next).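

In this assay, tert-butoxy in place of propyl on this aromatic carbon gives a 2.4-fold higher number from compound 2 to compound 3 (0.39 log units; beyond the scatter), so a second alkoxy group now stands on the higher side of propyl, and the earlier difference is no longer tied to a single alkoxy group. Changing the group on the oxygen, tert-butyl in place of butyl, gives a 1.1-fold higher number from compound 1 to compound 3 (0.04 log units; within the scatter), and so the straight and the branched chain on the oxygen cannot be told apart here.

The compounds shown leave open whether a smaller alkoxy group such as methoxy would follow compounds 1 and 3 or come closer to compound 2. They also leave open how a tert-butyl group joined directly to the ring, an amine or a carboxylic acid on this carbon would compare. Nothing given here accounts for these numbers.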